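Directly Attached Aryl Groups on the Shared Core

The source may report more compounds than this note shows. Statements on the series, on what has been measured and on what is new or still open speak of the compounds shown alone.

Among the measured compounds shown here, compound 3 `COc1cccc(-c2ccc([C@H]3S[C@@H](C)C(=O)Nc4c3c(C)nn4-c3ccccc3C)cc2)c1` gives 41% in an assay on isolated protein for agonist activity at Bile acid receptor (Homo sapiens), read by AlphaScreen, with a stated time of 30 min (on this read-out lower numbers stand for smaller maximal responses and higher numbers for larger maximal responses), the lowest of the three numbers so far; compound 1 `Cc1ccccc1-n1nc(C)c2c1NC(=O)[C@H](C)S[C@@H]2c1ccc(Oc2ccccc2)cc1` gives 118% and compound 2 `COc1cccc(Oc2ccc([C@H]3S[C@@H](C)C(=O)Nc4c3c(C)nn4-c3ccccc3C)cc2)c1` gives 120%. Compound 4 `Cc1ccccc1-n1nc(C)c2c1NC(=O)[C@H](C)S[C@@H]2c1ccc(-c2ccco2)cc1` differs from compound 3 by furan-2-yl in place of 3-methoxyphenyl on an aromatic carbon. For the measured compounds named here, the steps that bear on the aryl-bearing position are a number 77 percentage points lower from compound 1 to compound 3 (beyond the scatter) and a number 79 percentage points lower from compound 2 to compound 3 (beyond the scatter), both large drops; no measured pair swaps one directly attached aryl for another, so the size of such a step is not known. Compound 4 keeps the directly attached arrangement of compound 3 and is therefore expected to stay low, with a step of a number 9 percentage points higher from compound 3 to compound 4 (within the scatter) that may be in either direction. Compound 4 is estimated at 50%, between 20% and 95%.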

Compound 4, largest response reached (reported as efficacy), in percent of the reference or control that the assay uses: 32%
Compound 4: the middle estimate sits 18 percentage points above what was measured, and the stated range covers the measured number.
By their numbers in this assay, from the lowest: compounds 4 and 3 (each within the scatter of the next); then compounds 1 and 2 (each within the scatter of the next).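

In this assay, one directly attached aryl can now be compared with another: furan-2-yl and 3-methoxyphenyl do not separate (a number 9 percentage points lower from compound 3 to compound 4 (within the scatter)), despite the change from a six-membered to a five-membered aromatic ring. The large drop from the oxygen-linked groups also appears with this second directly attached ring (a number 86 percentage points lower from compound 1 to compound 4 (beyond the scatter); a number 88 percentage points lower from compound 2 to compound 4 (beyond the scatter)). No measurement available here explains this. Open, going by these compounds, is whether a directly attached ring carrying an amine or a carboxylic acid stays as low as compound 3 and compound 4. Also open, on these data alone, is whether furan-2-yloxy would match compound 1.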